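From ethyl to thiophen-3-yl on compound 2

The compounds below may be only part of what the source reports. "The series", "measured", "known", "first", "only" and "open" are said of these compounds alone.

Within the data shown here, in a functional assay on Jurkat cells (Homo sapiens) for inhibition (on this read-out lower numbers stand for stronger inhibition and higher numbers for weaker inhibition), compound 2 `CCOC(=O)c1cnc(N(C)N2C(=O)C=C(C)C2=O)nc1CC` gives 35 nM, the lowest of the three numbers so far. Compound 1 `CCOC(=O)c1cnc(NN2C(=O)C=C(C)C2=O)nc1CC` gives 400 nM, and compound 3 `CCc1nc(N(C)N2C(=O)C=C(C)C2=O)ncc1C(=O)c1ccccc1` gives 410 nM. Both measured steps are large: an 11-fold lower number from compound 1 to compound 2 (1.06 log units; beyond the scatter) came with methyl in place of hydrogen on a nitrogen, and a 12-fold higher number from compound 2 to compound 3 (1.07 log units; beyond the scatter) with phenyl in place of ethoxy on a carbonyl carbon. Compound 4 `CCOC(=O)c1cnc(N(C)N2C(=O)C=C(C)C2=O)nc1-c1ccsc1` instead has thiophen-3-yl in place of ethyl on an aromatic carbon. Among the measured compounds shown here, no measured step changes that ethyl, so these steps show only that single changes elsewhere can move the number far. A modest rise is expected, estimated as a 2.0-fold higher number from compound 2 to compound 4 (0.30 log units; within the scatter). For compound 4 the expected value is 70 nM, with an estimated range from 15 nM to 350 nM.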

Compound 4, half-maximal inhibitory concentration: 120 nM
Estimate against measurement, compound 4: 1.7-fold (0.23 log units) below; the measured number falls inside the stated range.
By their numbers in this assay, from the lowest: compound 2; then compound 4; then compounds 1 and 3 (each within the scatter of the next).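

In this assay, thiophen-3-yl in place of ethyl gives a 3.4-fold higher number from compound 2 to compound 4 (0.54 log units; beyond the scatter) at this carbon next to the ring nitrogen. Among these compounds, this is the first look at this position, and it shows that the number responds to the group placed here. The step is modest, so this position tolerates a ring of five heavy atoms in place of a two-carbon chain. No measurement at hand accounts for the rise. Still open, as far as these compounds go, is how a methyl, a propyl chain or an amine would compare at this carbon.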